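The source may report more compounds than this note shows. Statements on the series, on what has been measured and on what is new or still open speak of the compounds shown alone.

Of the compounds shown here, three with a shared core have been measured. Compound 1 `COc1ccccc1N1CCN(CCCNc2ncccc2C(=O)N(C)C)CC1` in a functional assay on aorta for antagonist activity at Alpha-1D adrenergic receptor (Rattus norvegicus) (on this read-out lower numbers stand for tighter binding and higher numbers for weaker binding), gives 20 nM. Compound 2 `COc1ccccc1N1CCN(CCCNc2ccc(C(=O)N(C)C)cn2)CC1` in this assay gives 31.6 nM, and compound 3 `COc1ccccc1N1CCN(CCCOc2ccccc2C(=O)N(C)C)CC1` in this assay gives 31.6 nM. Compound 1 carries the lowest of the three numbers, yet its gaps to compound 2 and to compound 3 both lie within the usual scatter, so the three cannot be put in order on this evidence. For the measured compounds named here, no pair among the measured compounds differs in only one place, so no single-change step is available to guide expectations.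

Compound 4 `CN(C)C(=O)c1cccnc1NCCCN1CCN(c2ccccc2Cc2ccccc2)CC1` is the next compound to be examined. Relative to compound 1 it shows (benzyl in place of methoxy on an aromatic carbon). Since nothing in the measured set speaks to such a change at that position, the expected step is none beyond the scatter, with a wide margin in either direction. Compound 4 is therefore estimated at 30 nM, between 8 nM and 120 nM, a step of a 1.5-fold higher number from compound 1 to compound 4 (0.18 log units; within the scatter) that is expected rather than known.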

Compound 4, dissociation constant: 79.4 nM
Compound 4: the middle estimate sits 2.6-fold (0.42 log units) below what was measured; the measured number falls inside the stated range.
By their numbers in this assay, from the lowest: compounds 1, 2 and 3 (each within the scatter of the next); then compound 4.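

In this assay, replacing methoxy with benzyl on this aromatic carbon, ortho to a large group, gives a 4.0-fold higher number from compound 1 to compound 4 (0.60 log units; beyond the scatter). For the compounds shown here, this is the first single-change step in the set, and it shows that the group at this place affects the read-out, which the earlier compounds could not show because none of them varied it. The step is modest, so this position accepts the larger benzyl, with its added six-membered aromatic ring, at a limited cost in this assay. No supporting evidence bears on why the number rises with this change.

The compounds shown leave open whether the rise follows the loss of the oxygen, the added carbons or the added ring, and an ethoxy, phenoxy or phenyl group at this place could help separate these. They also leave open whether benzyl in place of methoxy would give a similar step on the cores of compound 2 and compound 3.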